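The source may report more compounds than this note shows. Statements on the series, on what has been measured and on what is new or still open speak of the compounds shown alone.

Among the measured compounds shown here, compound 2 `Cc1ccc(S(=O)(=O)/N=C(/CCNC2=CC(=O)c3ccccc3C2=O)Nc2ccc(F)c(F)c2)cc1` is one of two compounds measured in an ADME assay on HEK293 cells (Homo sapiens) for cytotoxicity, read by MTT assay, with a stated time of 48 h (on this read-out higher numbers stand for weaker inhibition and lower numbers for stronger inhibition), where compound 2 gives 55200 nM; compound 1 `Cc1ccc(S(=O)(=O)/N=C(/CCNC2=CC(=O)c3ccccc3C2=O)Nc2ccccc2[N+](=O)[O-])cc1` gives 69600 nM in this assay, and the two numbers lie within the scatter of each other, so neither can be called the weaker or stronger. For the measured compounds named here, the one step measured so far, a 1.3-fold lower number from compound 1 to compound 2 (0.10 log units; within the scatter), exchanges the aryl group on the same amine nitrogen that is now changed again. Compound 3 `COc1ccc(N/C(CCNC2=CC(=O)c3ccccc3C2=O)=N\S(=O)(=O)c2ccc(C)cc2)c(OC)c1` differs from compound 2 in that (2,4-dimethoxyphenyl in place of 3,4-difluorophenyl on an amine nitrogen). Going by the values given here, the only step that bears on this change is the aryl exchange from compound 1 to compound 2, which stayed within the scatter, so the number for compound 3 in this assay is expected to move by no more than the scatter, with no direction favoured, and the step of a 1.0-fold lower number from compound 2 to compound 3 (0.00 log units; within the scatter) is expected to be small. Compound 3 is accordingly estimated at 55000 nM in this assay, in a range from 25000 nM to 120000 nM.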

Compound 3, half-maximal inhibitory concentration: 83000 nM
Compound 3: middle estimate off by 1.5-fold (0.18 log units), on the low side; the measured number falls inside the stated range.
By their numbers in this assay, from the lowest: compounds 2, 1 and 3 (each within the scatter of the next).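

In this assay the exchange of 3,4-difluorophenyl for 2,4-dimethoxyphenyl gives a 1.5-fold higher number from compound 2 to compound 3 (0.18 log units; within the scatter), and the exchange of 2-nitrophenyl for the same group gives a 1.2-fold higher number from compound 1 to compound 3 (0.08 log units; within the scatter). The earlier compounds offered a single aryl exchange on this amine nitrogen, whereas the three aryl groups, bearing nitro, fluorine or methoxy substituents, now all lie within the scatter of one another, so no substituent pattern shown here can be told apart on this read-out. Nothing available explains this result.

As far as these compounds go, all three compounds keep an aryl group on this nitrogen, so it remains open whether a saturated ring such as cyclohexyl would carry the number beyond the scatter. The same question stands for an aryl ring bearing a carboxylic acid.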